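The source may report more compounds than this note shows. Statements on the series, on what has been measured and on what is new or still open speak of the compounds shown alone.

Measured compounds, all in an assay on HEK293 cells for activation of Kir3.1/Kir3.2 (Homo sapiens), read by thallium flux; a lower number here means a smaller maximal response, a higher number a larger maximal response:
compound 1, `Cc1cc(NC(=O)Cn2nnc(-c3cccc(F)c3)n2)n(C2CCCCC2)n1`, 96%
compound 2, `Cc1cc(NC(=O)Cn2nnc(-c3ccnc(F)c3)n2)n(C2CCCCC2)n1`, 95%
compound 3, `Cc1cc(NC(=O)Cn2nnc(-c3ccc(C(F)(F)F)cc3)n2)n(C2CCCCC2)n1`, 94%

Compound 3 has the smallest of the three numbers, but the gaps are slight: the step of a number 1 percentage points lower from compound 2 to compound 3 (within the scatter) and the step of a number 2 percentage points lower from compound 1 to compound 3 (within the scatter) both stay within the scatter, so the three maximal responses are, for practical purposes, indistinguishable.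

The next compound, compound 4, `Cc1cc(NC(=O)Cn2nnc(-c3cccc(C#N)c3)n2)n(C2CCCCC2)n1`, has not yet been run in this assay. It differs from compound 3 in one place: 3-cyanophenyl in place of 4-(trifluoromethyl)phenyl on an aromatic carbon.

Within the data shown here, the steps that bear on this change are the ones that also exchanged the aryl group on that aromatic carbon: a number 1 percentage points lower from compound 1 to compound 2 (within the scatter), a number 2 percentage points lower from compound 1 to compound 3 (within the scatter) and a number 1 percentage points lower from compound 2 to compound 3 (within the scatter). Each of them was within the scatter, whether the group carried a fluorine, a ring nitrogen or a trifluoromethyl. Nothing in these three compounds suggests that the aryl group on this carbon moves the maximal response. A 3-cyanophenyl group has not been tried here, so the expectation rests on analogy alone.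

Compound 4 is therefore expected to give 95%, within a range of 85% to 103%, the expected step being a number 1 percentage points higher from compound 3 to compound 4 (within the scatter), which is no step beyond the scatter.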

Compound 4, largest response reached (Emax), in percent of the reference or control that the assay uses: 80%
The estimate for compound 4 lay 15 percentage points above the measured number, outside the stated range (below it).
By their numbers in this assay, from the lowest: compound 4; then compounds 3, 2 and 1 (each within the scatter of the next).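

In this assay, the aryl group on this aromatic carbon of the five-membered ring turns out not to be interchangeable, since the steps of a number 14 percentage points lower from compound 3 to compound 4 (beyond the scatter), a number 15 percentage points lower from compound 2 to compound 4 (beyond the scatter) and a number 16 percentage points lower from compound 1 to compound 4 (beyond the scatter) are all beyond the scatter, though modest in size. Among the four compounds, the tolerance seen for 3-fluorophenyl, 2-fluoropyridin-4-yl and 4-(trifluoromethyl)phenyl therefore does not extend to 3-cyanophenyl, and compound 4 alone stands apart from the other three, which stay within the scatter of one another. The comparison with compound 1 is the narrowest of the three, as only cyano in place of fluoro separates the two compounds, so a single exchange on the aryl ring is enough to lower the maximal response beyond the scatter.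

Whether this lower response is particular to the nitrile remains open, as the compounds shown do not tell whether a carboxamide, a methoxy group or a carboxylic acid in its place would give a similar result or keep the response of compound 1. The data shown include no measurement that accounts for the lower response of compound 4.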